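This account rests on a few compounds, and the source may have more. Where it says the series, first, only, none or still open, it means among the compounds named here.

Compound 1 `COc1cccc2occ(Cc3coc4ccccc4c3=O)c(=O)c12`, compound 2 `O=c1c(Cc2coc3cccc(OCC4CCCCC4)c3c2=O)coc2ccccc12` and compound 3 `CC(C)CCOc1cccc2occ(Cc3coc4ccccc4c3=O)c(=O)c12` share one core and differ only in the group on a saturated chain carbon bound to an oxygen on an aromatic ring. In a functional assay on PC-3 cells (Homo sapiens) for antiproliferative activity, read by XTT assay (on this read-out higher numbers stand for weaker inhibition and lower numbers for stronger inhibition), compound 1 gives 3490 nM. In this assay compound 2 gives 4510 nM. Compound 3 gives only a limit in this assay, > 10000 nM, which is the limit of > 10000 nM in this assay, at which 1 of the 3 values shown sits. Compound 3 thus stands at the weak end of the three, with its steps from compound 1 and compound 2 both beyond the scatter.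

Compound 4 `O=c1c(Cc2coc3cccc(OCc4ccccc4)c3c2=O)coc2ccccc12` differs from compound 3 by phenyl in place of isobutyl on a saturated chain carbon bound to an oxygen on an aromatic ring. For the measured compounds named here, two measured steps bear on it: a 1.3-fold higher number from compound 1 to compound 2 (0.11 log units; within the scatter), and an at least 2.2-fold higher number from compound 2 to compound 3 (0.34 log units; beyond the scatter). A phenyl at this place is expected to behave more like the cyclohexyl than like the isobutyl, which gives an expected step in this assay of an at least 1.6-fold lower number from compound 3 to compound 4 (0.22 log units; that floor lies within the scatter). Compound 4 is therefore estimated at 6000 nM, with a range from 2500 nM to 15000 nM.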

Compound 4, half-maximal inhibitory concentration: 4830 nM
For compound 4 the middle estimate is 1.2-fold (0.09 log units) above the measured one; the measured number falls inside the stated range.
By their numbers in this assay, from the lowest: compounds 1, 2 and 4 (each within the scatter of the next). At a limit, above all of these: compound 3.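

In this assay phenyl in place of isobutyl gives a clear change (an at least 2.0-fold lower number from compound 3 to compound 4 (0.31 log units; beyond the scatter)). The weak end of that step is a limit and not a number: the limit of > 10000 nM in this assay, at which 1 of the 4 values shown sits. Phenyl in place of cyclohexyl (a 1.1-fold higher number from compound 2 to compound 4 (0.03 log units; within the scatter)) and phenyl in place of hydrogen (a 1.4-fold higher number from compound 1 to compound 4 (0.14 log units; within the scatter)) both stay within the scatter, so an aromatic ring at this place reads the same as a saturated ring or no added group, and among the groups shown only isobutyl stands apart.

How far compound 3 actually lies from the others remains unsettled, since only its limit is available. As far as these compounds go, it also remains open whether this tolerance extends to a phenyl carrying a fluorine or a methoxy group, to a pyridine ring, or to a chain ending in an amine or a carboxylic acid.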